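Removing a Chloro Group from a Chalcone Thiourea

The source may hold more compounds than are shown below. What is called first, only, known or untested is meant among the compounds shown, and "the series" means these compounds.

Measured so far:
Compound 1 `Cc1ccc(/C=C/C(=O)c2ccc(NC(=S)Nc3ccc(Cl)cc3)cc2)cc1` gives 75.3% in a functional assay on the whole organism (Abdomen, strain Swiss) for inhibition, with Mus musculus as the target, with a stated time of 30 min, at a dose of 10 mg/kg by the intraperitoneal route; a higher number here means more inhibition at the dose given (going by the name of the read-out), a lower number less inhibition.
Compound 2 `O=C(/C=C/c1ccc(Cl)cc1)c1ccc(NC(=S)Nc2ccc(Cl)cc2)cc1` gives 100% in this assay.

Compound 2 stands highest of the two numbers in this assay. Compound 3 `O=C(/C=C/c1ccccc1)c1ccc(NC(=S)Nc2ccc(Cl)cc2)cc1` differs from it by hydrogen in place of chloro on an aromatic carbon. Among the measured compounds shown here, no measured step removes a chloro outright; the only related step, a number 24.7 percentage points higher from compound 1 to compound 2 (beyond the scatter), shows that exchanging methyl for chloro at this aromatic carbon raised the number. Because a number 24.7 percentage points higher from compound 1 to compound 2 (beyond the scatter) was modest, a loss of the chloro is expected to lower the number by a comparable amount, giving a number 25 percentage points lower from compound 2 to compound 3 (beyond the scatter). Compound 3 is therefore estimated at 75%, within 55% to 95%.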

Compound 3, a percentage reported as inhibition, in the whole organism at one dose (the size of the read-out at that dose, not a potency): 94.5%
Beside the measured number, compound 3's estimate is 19.5 percentage points below it; the measured number falls inside the stated range.
By their numbers in this assay, from the lowest: compound 1; then compounds 3 and 2 (each within the scatter of the next).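

In this assay the change from 4-chlorophenyl to phenyl gives a number 5.5 percentage points lower from compound 2 to compound 3 (within the scatter), so the chloro is not needed to keep the number high. The methyl compound is what stands apart, as hydrogen in place of methyl gives a number 19.2 percentage points higher from compound 1 to compound 3 (beyond the scatter) and lifts the number much as chloro did. No measurement here bears on the reason for this.

On these data alone, it remains open whether a methoxy group, an amine or a carboxylic acid at this position would match hydrogen and chloro or fall towards methyl.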